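The compounds below may be only part of what the source reports. "The series", "measured", "known", "first", "only" and "open" are said of these compounds alone.

Measured in an ADME assay on HepG2 cells (Homo sapiens) for cytotoxicity, read by MTT assay; a lower number here means a stronger inhibitor, a higher number a weaker inhibitor:
- compound 1 `O=C(NCc1ccccc1)Oc1ccc(Cl)cc1C(=O)Nc1ccc(Cl)cc1`: > 250000 nM (a limit)
- compound 2 `O=C(NC1CCCCC1)Oc1ccc(Cl)cc1C(=O)Nc1ccc(F)cc1`: 21200 nM
- compound 3 `O=C(Nc1ccccc1)Oc1ccc(Cl)cc1C(=O)Nc1ccc(Cl)cc1`: > 250000 nM (a limit)

Compound 1 is known only as a limit, > 250000 nM. Compound 3 is likewise recorded only as a limit, > 250000 nM. Of the three, compound 2 alone has a measured number, 21200 nM.

Compound 4 `O=C(NCc1ccccc1)Oc1ccc(Cl)cc1C(=O)Nc1ccc(Br)cc1` keeps the core of compound 1 and carries bromo in place of chloro on an aromatic carbon, para to a large group: bromo in place of chloro on an aromatic carbon. Going by the values given here, the one measured step gives no size to go on: a step that the two limits leave unreadable from compound 1 to compound 3. It also concerns a different part of the molecule. Among the compounds with values here, the only guide left is the limit of > 250000 nM in this assay, at which 2 of the 3 values shown sit, and with it no step beyond the scatter is expected in this assay. For compound 4 the expected value is about 250000 nM, with an estimated range of 100000 nM to 500000 nM. The estimated change is a number no higher from compound 1 to compound 4 (the limit leaves the size open).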

Compound 4, half-maximal inhibitory concentration: > 50000 nM
Compound 4 gave a limit, no number; the forecaster's own chance of this, stated with the estimate: 70%; the middle value lies beyond the limit too.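

In this assay, compound 1 is recorded only as a limit, > 250000 nM. Compound 4 is likewise recorded only as a limit, > 50000 nM. Going by these compounds alone, no step between compound 1 and compound 4 can be read. The compounds shown leave open whether bromo in place of chloro changes the value at all.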